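A few compounds are considered here, and "the series" means these few. Any claim that something is new, unique, unknown or untested is made for them only; others in the source may bear on it.

Working notes on the series.

Among the compounds with values here, compound 2 `CCCCNc1nc(N)nc(C)c1CCCN1CCCCCC1` gives 178 nM in an assay on HEK293 cells for agonist activity at Toll-like receptor 8 (Homo sapiens), read by spectrophotometry (on this read-out higher numbers stand for an effect only at larger amounts of compound and lower numbers for an effect already at smaller amounts), and stands lowest of the two numbers so far; its nearest neighbour, compound 1 `CCCCNc1nc(N)nc(C)c1CCC(C)(C)O`, gives 3140 nM in this assay, a gap that is beyond the usual scatter. The two differ in more than one place, so only their two values are compared here.

Compound 3 `CCCCCc1c(C)nc(N)nc1NCCCC` is the next entry and has not yet been measured. Relative to compound 2 the change is ethyl in place of azepan-1-yl on a saturated chain carbon, three bonds along the chain from an aromatic carbon. Within the data shown here, no single-change step between measured compounds is available, so the size of this step has no direct precedent. The expectation for this assay is that the change from compound 2 to compound 3 costs potency by an 11-fold higher number from compound 2 to compound 3 (1.05 log units; beyond the scatter), with the expectation resting on the pattern that compound 2 at 178 nM sits well below compound 1. Compound 3 is therefore estimated at 2000 nM in this assay, with a range of 500 nM to 8000 nM.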

Compound 3, half-maximal effective concentration: 1220 nM
Compound 3: middle estimate off by 1.6-fold (0.21 log units), on the high side, and the stated range covers the measured number.
By their numbers in this assay, from the lowest: compound 2; then compound 3; then compound 1.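

In this assay, within the data shown here, the step of a 6.9-fold higher number from compound 2 to compound 3 (0.84 log units; beyond the scatter) gives the first single-change reading at this position: with ethyl in place of azepan-1-yl on a saturated chain carbon, three bonds along the chain from an aromatic carbon, the number rises beyond the scatter. The second step, a 2.6-fold lower number from compound 1 to compound 3 (0.41 log units; beyond the scatter), has propyl in place of 1-hydroxy-1-methylethyl on a saturated chain carbon, two bonds along the chain from an aromatic carbon, so the end of this chain moves the number in both comparisons, and the plain alkyl chain sits between the other two groups. Nothing measured here bears on the reason for either step.

The compounds shown leave open whether the lower number of compound 2 follows the ring or its nitrogen; a dimethylamino group or a piperidin-1-yl group in the same place would separate the two. Going by these compounds, how a longer unbranched alkyl chain would read also remains open.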